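The source may hold more compounds than are shown below. What is called first, only, known or untested is meant among the compounds shown, and "the series" means these compounds.

In an in vitro ADME assay on microsomes (Rattus norvegicus) for metabolic stability (a lower number here means that the compound disappears faster, a higher number that the compound lasts longer), compound 1 (`CCc1nc(-c2ccc(Cl)cc2Cl)c(CC)nc1NC(COC)COC`) gives 0.0417 h. Compound 2 (`CCc1nc(-c2ccc(Cl)cc2Cl)c(CC)nc1NC(C)CN(C)C`) has only a limit to show, < 0.0167 h, and this is the limit of < 0.0167 h in this assay, at which 1 of the 3 values shown sits. Going by the values given here, the one measured step that bears directly on compound 2 is an at least 2.4-fold lower number from compound 1 to compound 2 (0.39 log units; beyond the scatter), which sets 1-((dimethylamino)methyl)ethyl in place of 2-methoxy-1-(methoxymethyl)ethyl. Compound 4 (`CCc1nc(-c2ccc(Cl)cc2Cl)c(CC)nc1NC(CC)CC`) keeps the core of compound 2 and carries pentan-3-yl in place of 1-((dimethylamino)methyl)ethyl on a nitrogen on an aromatic ring. The same pentan-3-yl amino arrangement appears on a different core in compound 3 (`CCC(CC)Nc1nc(OC)c(-c2ccc(Cl)cc2Cl)nc1OC`), which gives 0.0417 h. That value, together with the size of an at least 2.4-fold lower number from compound 1 to compound 2 (0.39 log units; beyond the scatter), points to a modest recovery rather than a large one. The expected change is an upward one, estimated as an at least 1.7-fold higher number from compound 2 to compound 4 (0.25 log units; that floor lies within the scatter). For compound 4 the estimated half-life is 0.03 h, with an expected range of 0.017 h to 0.07 h.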

Compound 4, half-life: 0.07 h
For compound 4 the middle estimate is 2.3-fold (0.37 log units) below the measured one; the range from low to high includes it.
By their numbers in this assay, from the lowest: compounds 1, 3 and 4 (each within the scatter of the next). At a limit, below all of these: compound 2.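

On the shared core, pentan-3-yl in place of 1-((dimethylamino)methyl)ethyl on a nitrogen on an aromatic ring gives, in this assay, an at least 4.1-fold higher number from compound 2 to compound 4 (0.62 log units; beyond the scatter). With a 1.7-fold higher number from compound 1 to compound 4 (0.22 log units; within the scatter), pentan-3-yl and 2-methoxy-1-(methoxymethyl)ethyl cannot be told apart at this position, and of the three groups compared on this core, only 1-((dimethylamino)methyl)ethyl stands apart. Compound 2 has a limit and not a number, so the full size of its step remains unknown: the limit of < 0.0167 h in this assay, at which 1 of the 4 values shown sits.

The compounds shown leave open whether the short half-life of compound 2 goes with the dimethylamino end itself or with the whole of that group. They also leave open whether a morpholine or a primary amine at this nitrogen would read like compound 2 or like compound 1 and compound 4.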